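A Methyl-to-Hydrogen Change at the Edge of Readability

A few compounds are considered here, and "the series" means these few. Any claim that something is new, unique, unknown or untested is made for them only; others in the source may bear on it.

Compound 1 `O=C(Nc1cccc(-n2cc(-c3ccncc3)c(-c3ccc(Cl)c(O)c3)n2)c1)Nc1cccc(C(F)(F)F)c1`: in a functional assay on SF-268 cells (Homo sapiens) for inhibition, read by sulforhodamine B assay, with a stated time of 48 h (on this read-out lower numbers stand for higher toxicity in this test and higher numbers for lower toxicity in this test), compound 1 gives > 32500 nM, which is a limit of the test rather than a number.
Compound 2 `O=C(Nc1cccc(-n2cc(-c3ccncc3)c(-c3ccc(Cl)c(O)c3)n2)c1)Nc1ccc(Cl)c(Cl)c1`: compound 2 gives > 32500 nM, also a limit.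
Compound 3 `COc1cc(-c2nn(-c3cccc(NC(=O)Nc4ccc(Cl)c(C(F)(F)F)c4)c3)cc2-c2ccncc2)ccc1Cl`: compound 3 gives > 32500 nM, again a limit.

Compound 3 thus stands at the edge of what this assay can read, as the limit of > 32500 nM in this assay, at which 3 of the 3 values shown sit, makes clear. Going by the values given here, the only step between two measured compounds, a step that the two limits leave unreadable from compound 1 to compound 2, has no readable size, both of its ends being limits. Compound 4 `O=C(Nc1cccc(-n2cc(-c3ccncc3)c(-c3ccc(Cl)c(O)c3)n2)c1)Nc1ccc(Cl)c(C(F)(F)F)c1` differs from compound 3 by hydrogen in place of methyl on an oxygen on an aromatic ring. Among the compounds with values here, no measured step shares this change, so nothing seen here argues for a move in either direction beyond the scatter. Compound 4 is therefore expected to give 40000 nM (range 15000 nM to 100000 nM), an expected step that the limit leaves unreadable from compound 3 to compound 4, most probably once more only a limit.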

Compound 4, concentration lethal to 50% of the cells: > 32500 nM
Compound 4: a limit, no number; the forecaster's own chance of this, stated with the estimate: 75%; the middle value does not contradict the limit.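

No step between compound 1, compound 2, compound 3 and compound 4 can be read, because each value is only a limit: the limit of > 32500 nM in this assay, at which 4 of the 4 values shown sit.

Left open is whether methoxy to hydroxy, or any other change among these compounds, alters the toxicity seen in this assay.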